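This account rests on a few compounds, and the source may have more. Where it says the series, first, only, none or still open, it means among the compounds named here.

Measured so far:
compound 1 `COc1cc(NC(=O)Nc2cc(Nc3ccc(F)c(Cl)c3)ncn2)cc(OC)c1`: 25.5%
compound 2 `COc1cc(NC(=O)Nc2cc(Nc3ccc(OC)c(C)c3)ncn2)cc(OC)c1`: 13.5%

Both numbers come from a functional assay on NCI-H520 cells (Homo sapiens) for inhibition, read by MTT assay, with a stated time of 48 h, tested at 10 uM; on this read-out lower numbers stand for less inhibition and higher numbers for more inhibition at the one concentration tested (going by the name of the read-out). Going by the values given here, compound 2 stands lowest of the two, with compound 1 the nearest and higher by a step beyond the scatter; the one measured step, a number 12 percentage points lower from compound 1 to compound 2 (beyond the scatter), exchanges the whole aryl group on the ring nitrogen, 3-chloro-4-fluorophenyl for 4-methoxy-3-methylphenyl.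

Compound 3 `COc1cc(NC(=O)Nc2cc(Nc3ccc(OC)c(I)c3)ncn2)cc(OC)c1` is not yet measured. Against compound 2 the change is iodo in place of methyl on an aromatic carbon, so the 4-methoxy-3-methylphenyl becomes 3-iodo-4-methoxyphenyl. Among the compounds with values here, the only step that bears on it is the modest drop from compound 1 to compound 2, where a halogen-bearing aryl gave the higher number; compound 3 returns a halogen to the ring, though in a different arrangement, and the methoxy group stays. In this assay a small rise, smaller than that step, is therefore expected, though a number within the scatter of compound 2 would not surprise. Compound 3 is estimated at 20% (range 5% to 38%). The expected step is a number 6.5 percentage points higher from compound 2 to compound 3 (within the scatter).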

Compound 3, a percentage reported as inhibition, at one concentration (the size of the read-out at that concentration, not a potency): 46.5%
Compound 3: the middle estimate sits 26.5 percentage points below what was measured; measured number above the stated range.
By their numbers in this assay, from the lowest: compound 2; then compound 1; then compound 3.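

In this assay, exchanging methyl for iodo on the aromatic carbon ortho to a methoxy group, with all else kept, gives a number 33 percentage points higher from compound 2 to compound 3 (beyond the scatter) as a large step, so the number responds strongly to the group at this one position. The 3-iodo-4-methoxyphenyl also sits well clear of the 3-chloro-4-fluorophenyl, with a number 21 percentage points higher from compound 1 to compound 3 (beyond the scatter) on that exchange, so a methoxy-bearing aryl is not tied to the low number of compound 2, and a halogen on the aryl does not by itself fix the level. Nothing measured here accounts for the rise.

Open, on these data alone, is whether bromo or chloro at this position would give a number nearer compound 3 or compound 2. Also open, as far as these compounds go, is whether a hydroxy group or an amine in place of the methoxy group would keep the number of compound 3.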